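The compounds below may be only part of what the source reports. "The series", "measured", "known", "first", "only" and "open" are said of these compounds alone.

Of the compounds shown here, three built on one shared core have been tested so far. Compound 1 `O=C(C1CC1)N1CCN(Cc2nc3ccccc3n2Cc2ccc(F)cc2)CC1`, compound 2 `O=C(C1CC1)N1CCN(Cc2nc3ccccc3n2Cc2ccc(Cl)cc2)CC1` and compound 3 `O=C(C1CC1)N1CCN(Cc2nc3ccccc3n2Cc2cccc(Cl)c2)CC1` differ only in the group that hangs from the saturated chain carbon bound to an aromatic nitrogen. In an assay on isolated protein for inhibition of aldehyde dehydrogenase 1A1 (Homo sapiens), read by spectrophotometry, tested at 10 uM (a higher number here means more inhibition at the concentration tested (going by the name of the read-out), a lower number less inhibition), compound 1 gives 32.7%, compound 2 gives 56.6% and compound 3 gives 71.6%, so compound 3 stands highest of the three.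

Two of the measured steps matter for what follows. Swapping the halogen, (fluoro in place of chloro on an aromatic carbon), gave a number 23.9 percentage points lower from compound 2 to compound 1 (beyond the scatter). Moving the chlorine around the ring, (3-chlorophenyl in place of 4-chlorophenyl on a saturated chain carbon bound to an aromatic nitrogen), gave a number 15 percentage points higher from compound 2 to compound 3 (beyond the scatter).

Compound 4 `O=C(C1CC1)N1CCN(Cc2nc3ccccc3n2Cc2cccc(F)c2)CC1` has not yet been measured in this assay. It is made from compound 3 by fluoro in place of chloro on an aromatic carbon. For the measured compounds named here, this is the same kind of change as the one from compound 2 to compound 1, but not the same: there the fluorine sat para to a large group, here it sits meta to a large group.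

On the strength of the earlier halogen swap, the step from compound 3 to compound 4 is expected to be a number 23.6 percentage points lower from compound 3 to compound 4 (beyond the scatter), a drop of similar size, because the measured swap gave a number 23.9 percentage points lower from compound 2 to compound 1 (beyond the scatter). Compound 4 is therefore estimated at 48%, with a plausible range from 30% to 65%.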

Compound 4, a percentage reported as inhibition, at one concentration (the size of the read-out at that concentration, not a potency): 27.2%
The estimate for compound 4 lay 20.8 percentage points above the measured number; measured number below the stated range.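

In this assay, fluoro in place of chloro lowers the number on both the 4-substituted and the 3-substituted compounds, but by clearly different amounts: the same change on two cores in this assay, a number 23.9 percentage points lower (beyond the scatter) from compound 2 to compound 1 and a number 44.4 percentage points lower (beyond the scatter) from compound 3 to compound 4, 20.5 percentage points apart, beyond the scatter of two such steps. On the 3-substituted pair alone, the swap gives a number 44.4 percentage points lower from compound 3 to compound 4 (beyond the scatter). The direction of the change therefore carried over from one core to the other in these two pairs, but its size did not, so the drop measured on one core would not have given a safe figure for the other. Moving the halogen also behaves differently with fluoro than with chloro: the move from the 4-fluorophenyl to the 3-fluorophenyl group gives a number 5.5 percentage points lower from compound 1 to compound 4 (within the scatter), so those two compounds cannot be told apart, while the step that changes both halogen and position gives a number 29.4 percentage points lower from compound 2 to compound 4 (beyond the scatter), and two pairs show neither why the swap costs more on compound 3 nor that the same would hold on any other core.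

Still open, going by these compounds, is whether a bromo, methyl or methoxy group at the same place on the ring would track the chloro or the fluoro compounds. Also open, on these data alone, is whether the halogen swap would keep its direction with an amine or a carboxylic acid elsewhere on the shared core.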